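Working notes: carbonyl substituents, compound 3 to compound 4

This account rests on a few compounds, and the source may have more. Where it says the series, first, only, none or still open, it means among the compounds named here.

Measured so far in an ADME assay on HepG2 2.2.15 cells (Homo sapiens) for cytotoxicity; a lower number here means that less compound is tolerated, a higher number that more compound is tolerated
- compound 1 `CC(C)C(=O)OCCc1c(-c2ccccc2Cl)c2cc(Cl)ccc2[nH]c1=O` gives 62000 nM
- compound 2 `CCOCC(=O)OCCc1c(-c2ccccc2Cl)c2cc(Cl)ccc2[nH]c1=O` gives 130000 nM
- compound 3 `CC(=O)NCC(=O)OCCc1c(-c2ccccc2Cl)c2cc(Cl)ccc2[nH]c1=O` gives 110000 nM

Compound 3, at 110000 nM, cannot be separated from either of the other two: a 1.2-fold lower number from compound 2 to compound 3 (0.07 log units; within the scatter) and a 1.8-fold higher number from compound 1 to compound 3 (0.25 log units; within the scatter). Compound 4 `O=C(OCCc1c(-c2ccccc2Cl)c2cc(Cl)ccc2[nH]c1=O)c1ccc([N+](=O)[O-])cc1` is not yet measured in this assay. It differs from compound 3 as follows: 4-nitrophenyl in place of acetamidomethyl on a carbonyl carbon. All three measured steps change this same carbonyl substituent. Only a 2.1-fold higher number from compound 1 to compound 2 (0.32 log units; beyond the scatter) clears the scatter, and it is modest. Among the compounds with values here, none of the measured compounds carries an aromatic ring at this carbonyl carbon, so the 4-nitrophenyl case is an extrapolation. The small size of these steps argues against a large move. A slight lean to the lower side rests only on compound 1 at 62000 nM. Within the data shown here, no step clearly beyond the scatter is therefore expected. The expected step is a 1.7-fold lower number from compound 3 to compound 4 (0.23 log units; within the scatter). For compound 4 the estimated value is 65000 nM, with an expected range of 25000 nM to 150000 nM.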

Compound 4, half-maximal cytotoxic concentration: 1600000 nM
Compound 4: the middle estimate sits 25-fold (1.39 log units) below what was measured; measured number above the stated range.
By their numbers in this assay, from the lowest: compounds 1, 3 and 2 (each within the scatter of the next, the first and the last beyond it); then compound 4.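

In this assay, this carbonyl position proves far less flat than the earlier non-aromatic substituents suggested, with 4-nitrophenyl giving large steps whichever group it replaces: acetamidomethyl (a 15-fold higher number from compound 3 to compound 4 (1.16 log units; beyond the scatter)), ethoxymethyl (a 12-fold higher number from compound 2 to compound 4 (1.09 log units; beyond the scatter)) and isopropyl (a 26-fold higher number from compound 1 to compound 4 (1.41 log units; beyond the scatter)). All three steps run the same way, toward more compound tolerated, and each exceeds every step among compound 1, compound 2 and compound 3, so the identity of this substituent can matter strongly for this read-out. Nothing available explains the size of this change.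

The change brings in the aromatic ring and the nitro group together, so the shift cannot be assigned to either one alone. An unsubstituted phenyl, a 4-aminophenyl and a 4-methoxyphenyl at this carbonyl carbon would separate the contribution of the ring from that of the nitro group.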